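A few compounds are considered here, and "the series" means these few. Any claim that something is new, unique, unknown or untested is made for them only; others in the source may bear on it.

In a functional assay on A549 cells (Homo sapiens) for antiproliferative activity, read by MTT assay (a lower number here means a stronger inhibitor, a higher number a weaker inhibitor), the measured compounds stand as follows:
- compound 1 `COc1cccc(Nc2nccc(-c3ccc(F)cc3)n2)c1` gives 35900 nM
- compound 2 `COc1ccc(-c2ccnc(Nc3cccc(OC)c3)n2)cc1` gives 6530 nM
- compound 3 `Cc1cccc(Nc2nccc(-c3ccc(Cl)cc3Cl)n2)c1` gives 18500 nM

Compound 3 holds the second highest of the three numbers, within the scatter of compound 1 and beyond the scatter above compound 2. Compound 4 `COc1cccc(Nc2nccc(-c3ccc(Cl)cc3Cl)n2)c1` differs from it by methoxy in place of methyl on an aromatic carbon and is otherwise the same. Among the compounds with values here, the only measured step, a 5.5-fold lower number from compound 1 to compound 2 (0.74 log units; beyond the scatter), is modest, but it is methoxy in place of fluoro, a different exchange, so it bears only loosely here. Within the data shown here, no measured step covers methyl to methoxy, and only a small change is expected, if anything slightly downward. The expected step is a 1.3-fold lower number from compound 3 to compound 4 (0.12 log units; within the scatter) and stays small. Compound 4 is estimated at 14000 nM (expected range 5000 nM to 40000 nM).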

Compound 4, half-maximal inhibitory concentration: 32200 nM
Beside the measured number, compound 4's estimate is 2.3-fold (0.36 log units) below it; low and high end bracket the measured number.
By their numbers in this assay, from the lowest: compound 2; then compounds 3, 4 and 1 (each within the scatter of the next).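

In this assay the exchange of methyl for methoxy on an aromatic carbon, meta to a large group, gives a 1.7-fold higher number from compound 3 to compound 4 (0.24 log units; within the scatter) and so has no readable effect at this position. Within the data shown here, the only earlier step, a 5.5-fold lower number from compound 1 to compound 2 (0.74 log units; beyond the scatter), lay elsewhere in the molecule and showed nothing about this place. No measured property of these compounds bears on the result.

As far as these compounds go, whether an amine, a hydroxyl or a longer chain at this position would move the number beyond the scatter stays open. From the compounds shown here alone, it is also open whether methyl and methoxy would still read alike with other groups in place of the two chloro groups.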